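The compounds below may be only part of what the source reports. "The series", "measured", "known", "first", "only" and "open" are said of these compounds alone.

Compound 2 `CC(C)[C@H](NC(=O)COc1cccc2ccccc12)C(=O)N[C@@H](CC(=O)O)C(=O)CSc1nnnn1C` is one of three compounds tested in a functional assay on Jurkat cells (Homo sapiens) for inhibition; on this read-out higher numbers stand for weaker inhibition and lower numbers for stronger inhibition. Compound 2 reaches only the limit of the assay, with > 200000 nM. Compound 3 `CC(C)[C@H](NC(=O)COc1cccc2ccccc12)C(=O)N[C@@H](CC(=O)O)C(=O)COc1ccccn1` likewise stops at the limit, with > 200000 nM. Only compound 1 `COC(=O)c1cc(OCC(=O)[C@H](CC(=O)O)NC(=O)[C@@H](NC(=O)COc2cccc3ccccc23)C(C)C)no1` gives a number, and in this assay compound 1 shows 71000 nM. On these numbers compound 2 stands no better than the weakest end of the set, since two of the three values sit at the same limit (the limit of > 200000 nM in this assay, at which 2 of the 3 values shown sit).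

Compound 4 `CC(C)[C@H](NC(=O)COc1cccc2ccccc12)C(=O)N[C@@H](CC(=O)O)C(=O)COn1nnc2ccccc2c1=O` has not yet been measured. It differs from compound 2 in one place: a group of 12 heavy atoms (7 carbon, 3 nitrogen, 2 oxygen; one six-membered aromatic ring of carbon only, one six-membered aromatic ring with 3 hetero atoms) in place of a group of 7 heavy atoms (2 carbon, 4 nitrogen, 1 sulfur; one five-membered aromatic ring with 4 hetero atoms), on a saturated chain carbon bound to a carbonyl carbon.

Among the compounds with values here, two measured steps bear on this change. Replacing the 5-(methoxycarbonyl)-1,2-oxazol-3-yl ether by the tetrazolyl sulfide gave an at least 2.8-fold higher number from compound 1 to compound 2 (0.44 log units; beyond the scatter), and the pyridinyl ether gave an at least 2.8-fold higher number from compound 1 to compound 3 (0.44 log units; beyond the scatter). The step between the two limit-bound compounds, a step that the two limits leave unreadable from compound 2 to compound 3, cannot be read. Two of the three groups tried at this position gave only a limit; the third gave a weak but measurable inhibition. The new group is again an ether at the saturated chain carbon, so a modest move back toward a measurable number is expected, as an at least 1.6-fold lower number from compound 2 to compound 4 (0.22 log units; that floor lies within the scatter).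

Compound 4 is therefore estimated to give 120000 nM in this assay, within a range from 30000 nM to 400000 nM, with a real chance that only a limit is reported.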

Compound 4, half-maximal inhibitory concentration: 137000 nM
Estimate against measurement, compound 4: 1.1-fold (0.06 log units) below; the range from low to high includes it.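

In this assay compound 4 gives a second real number at this position, so a measurable read-out on the saturated chain carbon bound to a carbonyl carbon no longer rests on one group alone. The comparison with the other measured compound shows a 1.9-fold higher number from compound 1 to compound 4 (0.29 log units; within the scatter) and so, on this read-out, the two groups on oxygen cannot be told apart, even though they differ in their rings and heavy atoms. Against the two compounds that stop at a limit, the steps are only floors, with an at least 1.4-fold lower number from compound 2 to compound 4 (0.16 log units; that floor lies within the scatter) and with an at least 1.4-fold lower number from compound 3 to compound 4 (0.16 log units; that floor lies within the scatter) and so no real gain over the (1-methyl-1H-tetrazol-5-yl)sulfanyl or the (pyridin-2-yl)oxy group can yet be claimed.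

From the compounds shown here alone, how far compound 2 and compound 3 truly lie from compound 4 stays open, as both stop at a limit of the assay: the limit of > 200000 nM in this assay, at which 2 of the 4 values shown sit. Also open is whether an amine or a carboxylic acid on this saturated chain carbon, or a longer chain leading to the ring, would give a clearly lower number in this assay than any group shown here.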